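The source may report more compounds than this note shows. Statements on the series, on what has been measured and on what is new or still open speak of the compounds shown alone.

Compound 1 `COc1ccc(/C=C\C(=O)O)c(OCc2cn(-c3ccccc3C(=O)N3CCC(O)C3)nn2)c1CC=C(C)C`: a functional assay on NCI-H322 cells (Homo sapiens) for cytotoxicity, read by MTT assay, with a stated time of 24 h (on this read-out higher numbers stand for weaker inhibition and lower numbers for stronger inhibition), gives "not determined" (no result reported)
Compound 2 `COc1ccc(-n2cc(COc3c(/C=C\C(=O)O)ccc(OC)c3CC=C(C)C)nn2)cc1`: this assay gives "not determined" (no result reported)
Compound 3 `COc1ccc(/C=C\C(=O)O)c(OCc2cn(-c3ccccc3)nn2)c1CC=C(C)C`: this assay gives 29200 nM

Compound 2 stands without a number in this assay, and compound 1 is in the same position; the only figure in the set belongs to compound 3, which in this assay gives 29200 nM. Compound 4 `COc1ccc(/C=C\C(=O)O)c(OCc2cn(-c3ccc(NC(C)=O)cc3)nn2)c1CC=C(C)C` differs from compound 2 by acetamido in place of methoxy on an aromatic carbon. Going by the values given here, no measured pair differs at a single place, so no step can be sized from the numbers, and for the change from compound 2 to compound 4 nothing beyond the scatter is assumed in either direction in this assay. Taking compound 3 at 29200 nM as the sole anchor, compound 4 is expected near 25000 nM, with a range from 8000 nM to 80000 nM.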

Compound 4, half-maximal inhibitory concentration: 45700 nM
For compound 4 the middle estimate is 1.8-fold (0.26 log units) below the measured one; the range from low to high includes it.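

In this assay, going by these compounds alone, the first single-place comparison reads a 1.6-fold higher number from compound 3 to compound 4 (0.19 log units; within the scatter). On this aromatic carbon, para to a large group, acetamido in place of hydrogen therefore does not separate the two compounds. Nothing measured here bears on the reason for this result.

The comparison of methoxy with acetamido at this place cannot be read: compound 2 has no single number. From the compounds shown here alone, whether an amine or a carboxylic acid at the same place would give a step beyond the scatter remains open.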